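The source may report more compounds than this note shows. Statements on the series, on what has been measured and on what is new or still open speak of the compounds shown alone.

Three compounds of the series have numbers in an assay on mitochondria (strain BALB/c) for inhibition of glycerol-3-phosphate acyltransferase 1, mitochondrial (Mus musculus), read by scintillation counting, with a stated time of 10 min; on this read-out lower numbers stand for stronger inhibition and higher numbers for weaker inhibition. Compound 1 `CCCCCCCCS(=O)(=O)Nc1cc(-c2ccc(CCCC)cc2)ccc1C(=O)O` gives 15700 nM and compound 2 `CCCCCCCCS(=O)(=O)Nc1cc(-c2ccccc2OC)ccc1C(=O)O` gives 16100 nM, with a 1.0-fold higher number from compound 1 to compound 2 (0.01 log units; within the scatter). Compound 3 `CCCCCCCCS(=O)(=O)Nc1cc(/C=C/c2ccc(OC)cc2)ccc1C(=O)O` gives 38700 nM, the highest of the three; it stands beyond the scatter from both, with a 2.5-fold higher number from compound 1 to compound 3 (0.39 log units; beyond the scatter) and a 2.4-fold higher number from compound 2 to compound 3 (0.38 log units; beyond the scatter). Compound 4 `CCCCCCCCS(=O)(=O)Nc1cc(CCc2ccc(OC)cc2)ccc1C(=O)O` carries 2-(4-methoxyphenyl)ethyl in place of 2-(4-methoxyphenyl)ethenyl on an aromatic carbon. Within the data shown here, no measured step covers this change; the two steps that introduce the ethenyl linker only show modest increases against directly attached aryl groups, and they give no direct guidance on saturating the linker. The step in this assay is therefore expected to stay within the scatter, estimated as a 1.3-fold lower number from compound 3 to compound 4 (0.11 log units; within the scatter). Compound 4 is expected at 30000 nM, with a range from 12000 nM to 75000 nM.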

Compound 4, half-maximal inhibitory concentration: 43000 nM
For compound 4 the middle estimate is 1.4-fold (0.16 log units) below the measured one, within the range that was stated.
By their numbers in this assay, from the lowest: compounds 1 and 2 (each within the scatter of the next); then compounds 3 and 4 (each within the scatter of the next).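

In this assay, the ethyl and ethenyl linkers at this position cannot be told apart, with a 1.1-fold higher number from compound 3 to compound 4 (0.05 log units; within the scatter). The 2-(4-methoxyphenyl)ethyl group stands beyond the scatter from both directly attached aryl groups, with a 2.7-fold higher number from compound 2 to compound 4 (0.43 log units; beyond the scatter) and a 2.7-fold higher number from compound 1 to compound 4 (0.44 log units; beyond the scatter), so compounds 3 and 4 form one level and compounds 1 and 2 another. No evidence on hand accounts for this gap.

Open, from the compounds shown here alone, is whether an amide linker would stay at the level of compounds 3 and 4. Also open, going by these compounds, is what a hydroxy group or an amine in place of the methoxy group would do.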